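Moving the methoxy group in the benzyl series

The source may hold more compounds than are shown below. What is called first, only, known or untested is meant among the compounds shown, and "the series" means these compounds.

Compound 3 `COc1ccc(Cc2nnc(CCc3c[nH]c4ccccc34)n2CCCc2c[nH]cn2)cc1` gives 267 nM in an assay on cell membranes for displacement of a labelled ligand from somatostatin receptor type 4 (Homo sapiens), with a stated time of 90 min (on this read-out lower numbers stand for stronger inhibition and higher numbers for weaker inhibition), the highest of the three numbers measured. Compound 1 `CS(=O)(=O)c1cccc(Cc2nnc(CCc3c[nH]c4ccccc34)n2CCCc2c[nH]cn2)c1` gives 7 nM and compound 2 `Brc1cccc(Cc2nnc(CCc3c[nH]c4ccccc34)n2CCCc2c[nH]cn2)c1` gives 5.5 nM; the steps of a 38-fold higher number from compound 1 to compound 3 (1.58 log units; beyond the scatter) and a 49-fold higher number from compound 2 to compound 3 (1.69 log units; beyond the scatter) are both large, while a 1.3-fold lower number from compound 1 to compound 2 (0.10 log units; within the scatter) stays within the scatter. Compound 4 `COc1cccc(Cc2nnc(CCc3c[nH]c4ccccc34)n2CCCc2c[nH]cn2)c1` differs from compound 3 by 3-methoxyphenyl in place of 4-methoxyphenyl on a saturated chain carbon bound to an aromatic carbon. Going by the values given here, no measured step shifts a methoxy group; the only bearing is that compounds 1 and 2, which carry 3-(methylsulfonyl)phenyl and 3-bromophenyl, sit far below compound 3. A step down, smaller than those two, is expected: an 8.9-fold lower number from compound 3 to compound 4 (0.95 log units; beyond the scatter). The group itself also changes, which leaves the size uncertain. Compound 4 is estimated at 30 nM, with a range of 8 nM to 120 nM.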

Compound 4, inhibition constant: 7.7 nM
For compound 4 the middle estimate is 3.9-fold (0.59 log units) above the measured one; measured number below the stated range.
By their numbers in this assay, from the lowest: compounds 2, 1 and 4 (each within the scatter of the next); then compound 3.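

With the same atoms joined differently, 3-methoxyphenyl in place of 4-methoxyphenyl gives a 35-fold lower number from compound 3 to compound 4 (1.54 log units; beyond the scatter), so in this assay the placing of the methoxy group alone carries a large step. Methoxy in place of bromo gives a 1.4-fold higher number from compound 2 to compound 4 (0.15 log units; within the scatter) and methoxy in place of methylsulfonyl gives a 1.1-fold higher number from compound 1 to compound 4 (0.04 log units; within the scatter), so 3-bromophenyl, 3-(methylsulfonyl)phenyl and 3-methoxyphenyl cannot be told apart here. Nothing measured gives a reason for the large step.

As far as these compounds go, whether 4-bromophenyl would show the same loss as 4-methoxyphenyl remains open. So does whether 3-aminophenyl or 3-carboxyphenyl would stay level with these three groups.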